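Bromo to Ethynyl on the Aniline of Compound 1

This account rests on a few compounds, and the source may have more. Where it says the series, first, only, none or still open, it means among the compounds named here.

Measured compounds:
- compound 1, `Nc1ccccc1NC(=O)c1ccc(COc2ccc3ncnc(Nc4cccc(Br)c4)c3c2)cc1`: 1700 nM
- compound 2, `C#Cc1cccc(Nc2ncnc3cc(NC(=O)c4ccc(C(=O)Nc5ccccc5N)s4)ccc23)c1`: 960 nM

Both compounds were tested in a functional assay on A-431 cells (Homo sapiens) for cytotoxicity, read by resazurin assay; a higher number here means a weaker inhibitor, a lower number a stronger inhibitor. Compound 1 gives 1700 nM, the higher of the two numbers; compound 2 gives 960 nM, and the gap between these two values lies within the usual scatter, so no order between them can be read from the data.

Compound 3, `C#Cc1cccc(Nc2ncnc3ccc(OCc4ccc(C(=O)Nc5ccccc5N)cc4)cc23)c1`, has not been measured. It is built from compound 1 by one change: ethynyl in place of bromo on an aromatic carbon. For the measured compounds named here, compound 2 already carries the 3-ethynylphenyl group, though on a different linker, so it gives no direct step for this change. Going by the values given here, with no measured pair showing this single change, the expected step from compound 1 to compound 3 is estimated as small, a 1.4-fold lower number from compound 1 to compound 3 (0.15 log units; within the scatter), not clearly beyond the scatter. Compound 3 is therefore expected near 1200 nM, within a range of 450 nM to 3200 nM.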

Compound 3, half-maximal inhibitory concentration: 1600 nM
For compound 3 the middle estimate is 1.3-fold (0.12 log units) below the measured one; measured number inside the range.
By their numbers in this assay, from the lowest: compounds 2, 3 and 1 (each within the scatter of the next).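

In this assay, for the compounds shown here, the exchange of 3-bromophenyl for 3-ethynylphenyl can now be read directly for the first time, and it gives a 1.1-fold lower number from compound 1 to compound 3 (0.03 log units; within the scatter). At this place, on an aromatic carbon meta to a large group, bromo and ethynyl therefore cannot be told apart in this cell assay, even though ethynyl brings 2 heavy atoms where bromo has 1. No supporting measurement helps to interpret this result.

The compounds shown contain only these two groups at this place, so it remains open whether an amine, a carboxylic acid or a longer chain there would give a clearly different number. As far as these compounds go, it is also open whether the same exchange would read alike in a compound with a different linker.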